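Series notes: chain and terminal group change from compound 3

This account rests on a few compounds, and the source may have more. Where it says the series, first, only, none or still open, it means among the compounds named here.

Three compounds of this series have numbers in a functional assay on cells for antagonist activity at C-X-C chemokine receptor type 4 (Homo sapiens), read by fluorescence and calcium flux, with stated times of 25 min and 90 s; on this read-out higher numbers stand for weaker inhibition and lower numbers for stronger inhibition. Compound 1 `c1cncc(CN(CCCCN(C[C@H]2Cc3ccccc3CN2)[C@H]2CCCc3cccnc32)Cc2cccnc2)c1` gives 471 nM, and compound 2 `c1ccc2c(c1)CN[C@@H](CN(CCCCN(Cc1ccncc1)Cc1ccncc1)[C@H]1CCCc3cccnc31)C2` gives 832 nM. Compound 3 `c1ccc2c(c1)CN[C@@H](CN(CCCCNCC1CCSCC1)[C@H]1CCCc3cccnc31)C2` gives 69.6 nM, the lowest of the three numbers; the nearest is compound 1, whose number is higher by a margin beyond the scatter, and the furthest is compound 2, also beyond the scatter. Among the compounds with values here, no single-change step between measured compounds is available.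

Compound 4 `C(=C/CN(C[C@H]1Cc2ccccc2CN1)[C@H]1CCCc2cccnc21)\CNCc1ccccn1` differs from compound 3 by a group of 11 heavy atoms (9 carbon, 2 nitrogen; one six-membered aromatic ring with 1 hetero atom) in place of a group of 11 heavy atoms (9 carbon, 1 nitrogen, 1 sulfur; one six-membered non-aromatic ring with 1 hetero atom), on a saturated chain carbon bound to an amine nitrogen. The group that enters resembles the groups carried by compound 1 and compound 2, which give higher numbers than compound 3 in this assay, but those compounds differ elsewhere as well, so they only loosely inform the step. A moderate step toward a higher number, likely beyond the scatter, is expected for compound 4, as a 2.9-fold higher number from compound 3 to compound 4 (0.46 log units; beyond the scatter). In this assay compound 4 is estimated at 200 nM, with a range from 60 nM to 650 nM.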

Compound 4, half-maximal inhibitory concentration: 58.3 nM
Beside the measured number, compound 4's estimate is 3.4-fold (0.54 log units) above it, outside the stated range (below it).
By their numbers in this assay, from the lowest: compounds 4 and 3 (each within the scatter of the next); then compounds 1 and 2 (each within the scatter of the next).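

In this assay, exchanging the terminal group gives a 1.2-fold lower number from compound 3 to compound 4 (0.08 log units; within the scatter), so this place on the chain accepts the group with one six-membered aromatic ring with 1 hetero atom as well as the one with a six-membered non-aromatic ring with 1 hetero atom. Within this pair, neither the aromatic ring nor the loss of sulfur moves the number beyond the scatter. The step also brings in a double bond outside aromatic rings, so the ring exchange and the chain change are read only together. No evidence is available to explain this result.

From the compounds shown here alone, what the double bond and the ring each contribute on their own remains open. Also open, going by these compounds, is how the number responds to a longer chain or to a carboxylic acid at the chain end.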